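The source may hold more compounds than are shown below. What is called first, only, known or untested is meant among the compounds shown, and "the series" means these compounds.

Compound 1 `CCOC(=O)c1c(-c2cccc(OC)c2)[nH]c2cc(Cl)c(OC)cc2c1=O`: > 21500 nM
Compound 2 `CCOC(=O)c1c(-c2cccc(-c3ccccc3)c2)[nH]c2cc(Cl)c(Cl)cc2c1=O`: > 21500 nM

In an ADME assay on BJ cells (Homo sapiens) for cytotoxicity, read by luminescence, with a stated time of 72 h (on this read-out lower numbers stand for an effect already at smaller amounts and higher numbers for an effect only at larger amounts of compound), compound 2 stands at > 21500 nM, which is a limit and not a number. Compound 1 gives > 21500 nM, also a limit. Compound 3 `CCOC(=O)c1c(-c2cccc(OC)c2)[nH]c2cc(Cl)c(Cl)cc2c1=O` has methoxy in place of phenyl on an aromatic carbon, meta to a large group: methoxy in place of phenyl on an aromatic carbon. Among the measured compounds shown here, no measured step shows what this change does in this assay. With both measured compounds at the limit of > 21500 nM in this assay, at which 2 of the 2 values shown sit, no step beyond the scatter is expected, and the estimated step is a step that the limit leaves unreadable from compound 2 to compound 3. Compound 3 is expected at 22000 nM, with an estimated range of 12000 nM to 30000 nM.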

Compound 3, half-maximal effective concentration: > 21500 nM
Compound 3 was reported as a limit (the forecaster's own chance of this, stated with the estimate: 85%); the middle value is on the limit's open side.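

No step can be read between compound 1, compound 2 and compound 3, since each is reported only as a limit: the limit of > 21500 nM in this assay, at which 3 of the 3 values shown sit. The compounds shown leave open what methoxy in place of phenyl, or chloro in place of methoxy, does in this assay.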